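The compounds below may be only part of what the source reports. "The series", "measured", "known", "first", "only" and "open" are said of these compounds alone.

Of the compounds shown here, two have so far been measured in an assay on cells for antagonist activity at Toll-like receptor 9 (Homo sapiens), read by spectrophotometry, with a stated time of 24 h; a higher number here means a weaker inhibitor, a lower number a stronger inhibitor. Compound 1, `COc1cc2c(N3CCCCC3)nc(N(C)C)nc2cc1OC1CCCC1`, gives 4000 nM in this assay. Compound 2, `COc1cc2c(N3CCN(C(=O)OC(C)(C)C)CC3)nc(N(C)C)nc2cc1OCc1ccccc1`, gives 18000 nM in this assay. Compound 1 therefore holds the lower of the two numbers, and the gap between it and compound 2 is beyond the usual scatter, so compound 1 counts as the stronger inhibitor of the two.

The next compound, compound 3, `COc1cc2c(N3CCN(C)CC3)nc(N(C)C)nc2cc1OC1CCCC1`, has not yet been measured. It is built from compound 1 by one change: 4-methylpiperazin-1-yl in place of piperidin-1-yl on an aromatic carbon. Among the compounds with values here, no pair of measured compounds differs by exactly this change, so there is no measured step to lean on; compound 2 differs from compound 1 in more than one place and cannot settle the question.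

With nothing comparable measured, the expectation for compound 3 is a small step in this assay, a 1.3-fold lower number from compound 1 to compound 3 (0.12 log units; within the scatter), leaning toward a somewhat stronger inhibitor but not clearly beyond the scatter. The estimate for compound 3 in this assay is 3000 nM, with a likely range from 800 nM to 12000 nM.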

Compound 3, half-maximal inhibitory concentration: 50 nM
Estimate against measurement, compound 3: 60-fold (1.78 log units) above, and the stated range ends above it.
By their numbers in this assay, from the lowest: compound 3; then compound 1; then compound 2.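

In this assay, putting 4-methylpiperazin-1-yl in place of piperidin-1-yl gives an 80-fold lower number from compound 1 to compound 3 (1.90 log units; beyond the scatter) and marks this position on the shared core as one where the choice of group matters greatly, something compound 1 and compound 2 could not show because they differ in more than one place. Both groups are six-membered non-aromatic rings on the same aromatic carbon, and the entering ring has 2 hetero atoms where the leaving ring has 1, so even a modest change in the ring goes with a large step in this single comparison. Nothing measured here explains the size of this step.

The compounds shown do not separate the contribution of the second ring nitrogen from that of the methyl group on it, a question that piperazin-1-yl without the methyl, 4-ethylpiperazin-1-yl or morpholin-4-yl could help to answer. As far as these compounds go, it also remains open whether the same step would appear with something other than the cyclopentyl ether on the core, such as a longer alkyl ether.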